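Replacing the methoxyphenyl arm of compound 1 with a pyrrolidine chain

The source may report more compounds than this note shows. Statements on the series, on what has been measured and on what is new or still open speak of the compounds shown alone.

Measured compounds:
compound 1, `COc1ccc(CNCc2c(-c3nnc(SC(C)C)n3-c3ccccc3)n(C)c3ccc(F)cc23)cc1`, 6.42
compound 2, `COc1ccc(CNCc2c(-c3nnc(SC(C)C)n3-c3ccccc3)n(C)c3ccccc23)cc1`, 6.27

In a physicochemical assay for lipophilicity (a lower number here means a more polar compound, a higher number a more lipophilic compound), compound 1 gives 6.42, the higher of the two numbers measured; its nearest neighbour is compound 2 with 6.27. Among the measured compounds shown here, the only measured step, a number 0.15 log units lower from compound 1 to compound 2 (within the scatter), falls within the scatter. Compound 3, `CC(C)Sc1nnc(-c2c(CNCCN3CCCC3)c3cc(F)ccc3n2C)n1-c1ccccc1`, has not yet been measured. It differs from compound 1 by (pyrrolidin-1-yl)methyl in place of 4-methoxyphenyl on a saturated chain carbon bound to an amine nitrogen. For the measured compounds named here, no measured step concerns this change: the step between compound 1 and compound 2 touches only a fluoro on an aromatic carbon, leaving nothing to lean on for this far larger swap. The expectation for compound 3 rests on the change alone and is therefore uncertain. Compound 3 is expected to give about 4.6, within 3.7 and 5.5. The estimate means a step of a number 1.82 log units lower from compound 1 to compound 3 (beyond the scatter), expected to be a fall well beyond the scatter.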

Compound 3, partition coefficient: 4.99
Compound 3: middle estimate off by 0.39 log units, on the low side; the measured number falls inside the stated range.
By their numbers in this assay, from the lowest: compound 3; then compounds 2 and 1 (each within the scatter of the next).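

In this assay, the arm on the saturated chain carbon bound to an amine nitrogen proves far more influential than the fluoro on an aromatic carbon, whose step stayed within the scatter: (pyrrolidin-1-yl)methyl in place of 4-methoxyphenyl gives a number 1.43 log units lower from compound 1 to compound 3 (beyond the scatter). This single swap replaces a six-membered aromatic ring of carbon only with a five-membered non-aromatic ring holding a hetero atom, so the fall cannot be divided between the loss of the aromatic ring and the arrival of the ring nitrogen. Nothing measured here accounts for the size of this fall.

The compounds shown leave open whether a morpholine or a piperidine in place of the pyrrolidine, or a longer chain leading to it, would give a similar number. They also leave open whether hydrogen in place of fluoro stays as small a change on this new arm.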